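The source may hold more compounds than are shown below. What is called first, only, known or untested is meant among the compounds shown, and "the series" means these compounds.

Measured compounds in an assay on HEK293 cells for inhibition of Steryl-sulfatase (Homo sapiens), tested at 1 uM; a lower number here means a weaker effect, a higher number a stronger effect of the compound at the concentration tested:
compound 1 `CCN(Cc1ccc(Br)cc1)c1cccc(C(=O)N2CCc3ccc(OS(N)(=O)=O)cc3C2)c1` gives 84.5%
compound 2 `CN(C)CCCN(Cc1ccccc1)c1cccc(C(=O)N2CCc3ccc(OS(N)(=O)=O)cc3C2)c1` gives 26%
compound 3 `CCN(Cc1cccnc1)c1ccc(C(=O)N2CCc3ccc(OS(N)(=O)=O)cc3C2)cc1` gives 85.2%

Compound 3 holds the highest of the three numbers, though compound 1 sits within the scatter of it, so the two cannot be ordered; compound 2 lies far below both, well beyond the scatter. Compound 4 `NS(=O)(=O)Oc1ccc2c(c1)CN(C(=O)c1ccc(N3CCCCC3)cc1)CC2` has not yet been measured. It differs from compound 3 in one place: piperidin-1-yl in place of ethyl((pyridin-3-yl)methyl)amino on an aromatic carbon. Among the compounds with values here, no pair of measured compounds shows this change, so its size is unknown. Compound 4 is expected to give 65% (range 35% to 90%) in this assay. That expectation means a moderate step down from compound 3, a number 20.2 percentage points lower from compound 3 to compound 4 (beyond the scatter), probably beyond the scatter but staying nearer compound 3 than compound 2.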

Compound 4, a percentage reported as inhibition, at one concentration (the size of the read-out at that concentration, not a potency): 38.3%
Beside the measured number, compound 4's estimate is 26.7 percentage points above it, within the range that was stated.
By their numbers in this assay, from the lowest: compound 2; then compound 4; then compounds 1 and 3 (each within the scatter of the next).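

In this assay, piperidin-1-yl in place of ethyl((pyridin-3-yl)methyl)amino on this aromatic carbon, para to a large group, gives a large loss, a number 46.9 percentage points lower from compound 3 to compound 4 (beyond the scatter). The number at this position therefore depends strongly on which amino group is attached. No measurement shown here accounts for the drop.

As far as these compounds go, it remains open whether the loss follows from removing the (pyridin-3-yl)methyl part or from closing the amine into a ring. A diethylamino or morpholin-4-yl group at this place would help separate those two changes.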